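From Compound 3 to Compound 4: Fluoro Gives Way to Methoxy

The source may report more compounds than this note shows. Statements on the series, on what has been measured and on what is new or still open speak of the compounds shown alone.

Three compounds have been measured in a functional assay on RAW264.7 cells (Mus musculus) for inhibition, with a stated time of 4 days; on this read-out higher numbers stand for weaker inhibition and lower numbers for stronger inhibition:

Compound 1, `COc1ccc(/C=C/C(=O)c2cccc(-n3cc(C(C)(C)O)nn3)c2)cc1O`: 17100 nM
Compound 2, `C=C(C)c1cn(-c2cccc(C(=O)/C=C/c3ccc(OC)c(O)c3)c2)nn1`: 7760 nM
Compound 3, `COc1ccc(/C=C/C(=O)c2cccc(-n3cc(-c4ccc(F)cc4)nn3)c2)cc1O`: 2500 nM

Compound 3 stands as the strongest inhibitor of the three, since both a 6.8-fold lower number from compound 1 to compound 3 (0.84 log units; beyond the scatter) and a 3.1-fold lower number from compound 2 to compound 3 (0.49 log units; beyond the scatter) lie beyond the scatter, as does a 2.2-fold lower number from compound 1 to compound 2 (0.34 log units; beyond the scatter). Compound 4, `COc1ccc(-c2cn(-c3cccc(C(=O)/C=C/c4ccc(OC)c(O)c4)c3)nn2)cc1`, keeps the 4-fluorophenyl-bearing core of compound 3 and changes only (methoxy in place of fluoro on an aromatic carbon). Among the measured compounds shown here, none of the measured steps alters a substituent on an aryl group; all three exchange the group itself, so they bear on this step only loosely. The step of a 1.1-fold higher number from compound 3 to compound 4 (0.05 log units; within the scatter) is therefore expected to stay within the scatter. Compound 4 is estimated at 2800 nM, within 1100 nM to 7000 nM.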

Compound 4, half-maximal inhibitory concentration: 6290 nM
Estimate against measurement, compound 4: 2.2-fold (0.35 log units) below; measured number inside the range.
By their numbers in this assay, from the lowest: compound 3; then compounds 4 and 2 (each within the scatter of the next); then compound 1.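

In this assay the position para to a large group proves sensitive to its substituent, a point the earlier exchanges of whole groups could not show: methoxy in place of fluoro gives a 2.5-fold higher number from compound 3 to compound 4 (0.40 log units; beyond the scatter) and so gives back part of the gain seen with 4-fluorophenyl. The 4-methoxyphenyl group gives a 1.2-fold lower number from compound 2 to compound 4 (0.09 log units; within the scatter) against 1-methylethenyl, yet it still holds a 2.7-fold lower number from compound 1 to compound 4 (0.43 log units; beyond the scatter) against 1-hydroxy-1-methylethyl. Nothing measured on these compounds explains the difference between fluoro and methoxy. Still open, as far as these compounds go, is how chloro, hydroxy or an amine at this position would compare with fluoro and methoxy.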